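A few compounds are considered here, and "the series" means these few. Any claim that something is new, unique, unknown or untested is made for them only; others in the source may bear on it.

In a physicochemical assay for solubility (on this read-out lower numbers stand for lower solubility and higher numbers for higher solubility), compound 1 `CSc1c(O)nc2ccc(C(F)(F)F)cc2c1-c1cc(Cl)ccc1O` reads < 1 ug/mL and that is a limit of the assay. Among the measured compounds shown here, compound 2 `OCCCSc1c(O)nc2ccc(C(F)(F)F)cc2c1-c1cc(Cl)ccc1O` reads 3 ug/mL as the only actual number at hand. Compound 3 `CCNC(CO)Sc1c(O)nc2ccc(C(F)(F)F)cc2c1-c1cc(Cl)ccc1O` differs from compound 2 through 1-(ethylamino)-2-hydroxyethyl in place of 3-hydroxypropyl on a sulfur on a sulfur whose other neighbour is an aromatic carbon. For the measured compounds named here, the one measured step of an at least 3.0-fold higher number from compound 1 to compound 2 (0.47 log units; beyond the scatter) also changed the group on that sulfur and is the only guide, so a modest rise is expected. The expected move is a 2.3-fold higher number from compound 2 to compound 3 (0.37 log units; beyond the scatter) and so of modest size in the same direction. Compound 3 is estimated at 7 ug/mL within a range from 2 ug/mL to 25 ug/mL on this assay readings.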

Compound 3, solubility: > 1900 ug/mL
Compound 3: a limit, no number (the forecaster's own chance of this, stated with the estimate: 10%); middle value at least 270-fold (2.43 log units) from the limit.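

On the sulfur whose other neighbour is an aromatic carbon, 1-(ethylamino)-2-hydroxyethyl gives an at least 630-fold higher number from compound 2 to compound 3 (2.80 log units; beyond the scatter) in this assay, and the same group gives an at least 1900-fold higher number from compound 1 to compound 3 (3.27 log units; beyond the scatter) on that read-out. The group on this sulfur therefore spans a far wider range than the earlier pair showed. The reading of compound 3 is a limit, not a number, so both steps have no known upper size: the limit of > 1900 ug/mL in this assay, at which 1 of the 3 values shown sits.

From the compounds shown here alone, it remains open how much of the step belongs to the ethylamino part and how much to the hydroxyl-bearing branch. A plain 2-aminoethyl chain or a carboxylic acid on the same sulfur would help to separate these parts.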